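Amide side-chain variation and solubility at low pH

A few compounds are considered here, and "the series" means these few. Any claim that something is new, unique, unknown or untested is made for them only; others in the source may bear on it.

Measured so far:
compound 1 `CCNC(=O)c1cc(N)c(Nc2ccc(C#N)cc2)cc1Oc1c(C)cc(/C=C/C#N)cc1C` — 69.4 ug/mL
compound 2 `Cc1cc(/C=C/C#N)cc(C)c1Oc1cc(Nc2ccc(C#N)cc2)c(N)cc1C(=O)NCCCO` — 19.9 ug/mL

Within the data shown here, in a physicochemical assay for solubility, read by HPLC, with a stated time of 4 h, at pH 2 (on this read-out higher numbers stand for higher solubility and lower numbers for lower solubility), compound 2 gives 19.9 ug/mL, the lower of the two numbers so far. Its nearest neighbour is compound 1, which in this assay gives 69.4 ug/mL. Among the measured compounds shown here, the only measured step in the pair is a 3.5-fold lower number from compound 1 to compound 2 (0.54 log units; beyond the scatter), which concerns the entry of hydroxymethyl on the amide-bound chain.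

Compound 3 `Cc1cc(/C=C/C#N)cc(C)c1Oc1cc(Nc2ccc(C#N)cc2)c(N)cc1C(=O)NCCC(F)F` differs from compound 2 by difluoromethyl in place of hydroxymethyl on a saturated chain carbon, two bonds along the chain from an amide-type nitrogen. For the measured compounds named here, no measured step covers this exchange directly; the step from compound 1 to compound 2 only shows what the arrival of hydroxymethyl did, not what its replacement by difluoromethyl will do. With that single reference point, a modest step downward is expected, a 1.7-fold lower number from compound 2 to compound 3 (0.22 log units; within the scatter), though a result within the scatter cannot be excluded. For compound 3 the expected number in this assay is 12 ug/mL, estimated between 4 ug/mL and 35 ug/mL.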

Compound 3, solubility: 57.6 ug/mL
Compound 3: middle estimate off by 4.8-fold (0.68 log units), on the low side; measured number above the stated range.
By their numbers in this assay, from the lowest: compound 2; then compounds 3 and 1 (each within the scatter of the next).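

In this assay, difluoromethyl in place of hydroxymethyl on this saturated chain carbon gives a 2.9-fold higher number from compound 2 to compound 3 (0.46 log units; beyond the scatter), so the lower number seen on the entry of hydroxymethyl does not extend to every group at this place. Difluoromethyl in place of hydrogen at the same place gives a 1.2-fold lower number from compound 1 to compound 3 (0.08 log units; within the scatter), which is within the scatter, leaving compound 2 as the only one of the three set apart on this read-out. No measurement at hand accounts for the difference between hydroxymethyl and difluoromethyl here.

On these data alone, whether the lower number is particular to hydroxymethyl remains open: an amine, a carboxylic acid or a methoxy group at this place would bear on that. Also open, as far as these compounds go, is how a longer chain carrying hydroxymethyl or difluoromethyl would read in this assay.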